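Moving one fluorine on a weak difluorophenyl compound

The source may report more compounds than this note shows. Statements on the series, on what has been measured and on what is new or still open speak of the compounds shown alone.

In a functional assay on Jurkat cells (Homo sapiens) (on this read-out lower numbers stand for stronger inhibition and higher numbers for weaker inhibition), compound 1 `CC(C)[C@H](NC(=O)COc1cccc2ccccc12)C(=O)N[C@@H](CC(=O)O)C(=O)COC(=O)c1c(Cl)cccc1Cl` gives 10600 nM, while compound 2 `CC(C)[C@H](NC(=O)COc1cccc2ccccc12)C(=O)N[C@@H](CC(=O)O)C(=O)COc1ccc(F)cc1F` gives 33200 nM, the higher and therefore weaker of the two numbers. Compound 3 `CC(C)[C@H](NC(=O)COc1cccc2ccccc12)C(=O)N[C@@H](CC(=O)O)C(=O)COc1cc(F)ccc1F` has 2,5-difluorophenyl in place of 2,4-difluorophenyl on an oxygen on a saturated carbon. Going by the values given here, the only measured step, a 3.1-fold higher number from compound 1 to compound 2 (0.50 log units; beyond the scatter), was modest and exchanged one group for a different kind of group. Here the same atoms stay, joined differently, so no change beyond the scatter is expected in this assay. The expected step is a 1.1-fold lower number from compound 2 to compound 3 (0.04 log units; within the scatter). Compound 3 is estimated at 30000 nM, with a range from 14000 nM to 65000 nM.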

Compound 3, half-maximal inhibitory concentration: > 100000 nM
Compound 3: no number, only a limit (the forecaster's own chance of this, stated with the estimate: 10%); middle value at least 3.3-fold (0.52 log units) away from the limit.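

In this assay compound 3 gives no number, only a limit of the assay: the limit of > 100000 nM in this assay, at which 1 of the 3 values shown sits. Moving one fluorine, with the same atoms kept, still gives an at least 3.0-fold higher number from compound 2 to compound 3 (0.47 log units; beyond the scatter) in going from 2,4-difluorophenyl to 2,5-difluorophenyl, so at this place the arrangement of the fluorines matters and not only the kind of group. Against the ester-linked group of compound 1, the change reads as an at least 9.4-fold higher number from compound 1 to compound 3 (0.97 log units; beyond the scatter) and is the largest step shown.

On these data alone, the true value of compound 3 stays unknown behind its limit. As far as these compounds go, whether a phenyl ring carrying an amine or a nitrile would do better here also stays open.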